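Swapping the Thiazole Amide for a Methylpyrazole

A few compounds are considered here, and "the series" means these few. Any claim that something is new, unique, unknown or untested is made for them only; others in the source may bear on it.

Compound 1 `N#Cc1cc(F)cc(C(=O)Nc2ccccn2)c1` and compound 2 `N#Cc1cc(F)cc(C(=O)Nc2nccs2)c1` share one core and differ only in the ring attached to the amide nitrogen. In an in vitro functional assay on HEK293-A cells for antagonist activity at metabotropic glutamate receptor 5 (Rattus norvegicus), read by calcium flux (a higher number here means a weaker inhibitor, a lower number a stronger inhibitor), compound 1 gives 3010 nM. Compound 2 reaches only the limit of this assay, recorded as > 10000 nM, so for compound 2 there is a bound and no number. Within the data shown here, the step of an at least 3.3-fold higher number from compound 1 to compound 2 (0.52 log units; beyond the scatter) is the single measured change here, and compound 2 sits at the limit of > 10000 nM in this assay, at which 1 of the 2 values shown sits.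

Compound 3 `Cn1ccc(NC(=O)c2cc(F)cc(C#N)c2)n1` has not yet been measured. The change from compound 2 to compound 3 is 1-methyl-1H-pyrazol-3-yl in place of 1,3-thiazol-2-yl on an amide-type nitrogen. Among the measured compounds shown here, no measured step covers this exchange; the only measured step, an at least 3.3-fold higher number from compound 1 to compound 2 (0.52 log units; beyond the scatter), concerns a different pair of rings, though it shows that a ring change at this nitrogen can move the number beyond the scatter. Because compound 2 stands at the limit of > 10000 nM in this assay, at which 1 of the 2 values shown sits, only a fall in number could be seen as a change. Compound 3 is expected to give 8000 nM, within 2000 nM to 30000 nM. The expected step of an at least 1.2-fold lower number from compound 2 to compound 3 (0.09 log units; that floor lies within the scatter) is estimated to be small, with a fair chance that compound 3 again meets only the limit.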

Compound 3, half-maximal inhibitory concentration: > 10000 nM
Compound 3: a limit, no number; the forecaster's own chance of this, stated with the estimate: 50%; middle value at least 1.2-fold (0.09 log units) away from the limit.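

Among the three rings shown on the amide-type nitrogen, only pyridin-2-yl gives a measurable potency in this assay, where compound 1 reads 3010 nM. Placing 1-methyl-1H-pyrazol-3-yl there instead gives an at least 3.3-fold higher number from compound 1 to compound 3 (0.52 log units; beyond the scatter), so a second five-membered aromatic ring with 2 hetero atoms, with different atoms and an added methyl group, now stands on the weak side of the pyridin-2-yl compound, just as 1,3-thiazol-2-yl did. The step between compound 2 and compound 3 cannot be read, and the two rings cannot be placed in order, because both compounds stop at the same limit rather than giving numbers: the limit of > 10000 nM in this assay, at which 2 of the 3 values shown sit.

Going by these compounds, how much weaker compound 2 and compound 3 really are stays unknown, and with only these three compounds nothing can be said about five-membered rings as a general class. On these data alone, it also remains open whether a methyl group or an amine on the pyridin-2-yl ring of compound 1 would give a stronger inhibitor, or would lose potency as these two ring exchanges did.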